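From propoxy to phenoxy on the shared core

The source may hold more compounds than are shown below. What is called first, only, known or untested is meant among the compounds shown, and "the series" means these compounds.

In an ADME assay for permeability, using PAMPA, at pH 7.4 (on this read-out lower numbers stand for lower permeability and higher numbers for higher permeability), compound 1 (`CCOC(=O)c1c(-c2cccc(OC)c2)[nH]c2cc(OC)ccc2c1=O`) gives 170 10^-6 cm/s, compound 2 (`CCOC(=O)c1c(-c2cccc(OCC)c2)[nH]c2cc(OC)ccc2c1=O`) gives 260 10^-6 cm/s, and compound 3 (`CCCOc1cccc(-c2[nH]c3cc(OC)ccc3c(=O)c2C(=O)OCC)c1`) gives 340 10^-6 cm/s. Compound 3 therefore stands within the scatter of both other compounds.

The next structure, compound 4 (`CCOC(=O)c1c(-c2cccc(Oc3ccccc3)c2)[nH]c2cc(OC)ccc2c1=O`), differs from compound 3 as follows: phenyl in place of propyl on an oxygen on an aromatic ring. In words, this is phenyl in place of propyl on an oxygen on an aromatic ring.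

The measured steps that bear on this change all alter the saturated chain on that oxygen: a 1.5-fold higher number from compound 1 to compound 2 (0.18 log units; within the scatter), a 2.0-fold higher number from compound 1 to compound 3 (0.30 log units; within the scatter), and a 1.3-fold higher number from compound 2 to compound 3 (0.12 log units; within the scatter). None of them places a ring on the oxygen, so they offer only indirect guidance. Since all three remain within the scatter, no step beyond the scatter is expected in this assay, and no direction is favoured. The estimated step is a 1.1-fold lower number from compound 3 to compound 4 (0.05 log units; within the scatter). For compound 4 the estimated value is 300 10^-6 cm/s. The expected range for compound 4 runs from 130 10^-6 cm/s to 650 10^-6 cm/s.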

Compound 4, apparent permeability: 750 10^-6 cm/s
Compound 4: middle estimate off by 2.5-fold (0.40 log units), on the low side, outside the stated range (above it).
By their numbers in this assay, from the lowest: compounds 1, 2 and 3 (each within the scatter of the next); then compound 4.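

In this assay, among the compounds shown here, phenyl on the oxygen gives the first steps at this position that lie beyond the scatter, with a 2.2-fold higher number from compound 3 to compound 4 (0.34 log units; beyond the scatter) and a 2.9-fold higher number from compound 2 to compound 4 (0.46 log units; beyond the scatter) and a 4.4-fold higher number from compound 1 to compound 4 (0.64 log units; beyond the scatter) all pointing the same way. Methyl, ethyl and propyl on this oxygen remain within the scatter of one another, so among these four compounds only the change from a saturated chain to phenyl separates one compound from the rest, and compound 4 gives the highest number. No measured evidence accounts for this step.

As far as these compounds go, whether the higher number goes with the aromatic ring or simply with the larger group stays open, and cyclohexyl or a longer chain such as hexyl on the same oxygen would separate the two. Also open, from the compounds shown here alone, is whether the number holds with an amine or a carboxylic acid on the phenyl.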